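Cyclohexyl to Cyclooctyl on the Amide Nitrogen

The source may hold more compounds than are shown below. What is called first, only, known or untested is meant among the compounds shown, and "the series" means these compounds.

- compound 1 `O=C(CCCCCCn1cc(C(=O)NCc2ccc(Cl)cc2)c2ccccc21)NO`: > 100000 nM (a limit, not a number)
- compound 2 `O=C(CCCCCCn1cc(C(=O)Nc2ccc(Cl)cc2Cl)c2ccccc21)NO`: 4500 nM
- compound 3 `O=C(CCCCCCn1cc(C(=O)NC2CCCCC2)c2ccccc21)NO`: 15000 nM

All three compounds were tested in a functional assay on HCT-116 cells (Homo sapiens) for antiproliferative activity, read by WST assay, with a stated time of 72 h; on this read-out higher numbers stand for weaker inhibition and lower numbers for stronger inhibition. Compound 1 gives > 100000 nM, which is a limit of the assay. Within the data shown here, only two true numbers therefore remain, and compound 3, at 15000 nM, holds the higher one, meaning weaker inhibition than its nearest neighbour: a 3.3-fold higher number from compound 2 to compound 3 (0.52 log units; beyond the scatter).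

Compound 4 `O=C(CCCCCCn1cc(C(=O)NC2CCCCCCC2)c2ccccc21)NO` changes one group of compound 3: cyclooctyl in place of cyclohexyl on an amide-type nitrogen. In words, this is cyclooctyl in place of cyclohexyl on an amide-type nitrogen. Among the measured compounds shown here, no measured step changes ring size alone. Swaps at this same nitrogen do matter, as an at least 22-fold lower number from compound 1 to compound 2 (1.34 log units; beyond the scatter) and an at least 6.6-fold lower number from compound 1 to compound 3 (0.82 log units; beyond the scatter) show, but they exchange very different groups and give no direction here. Both rings in the new change are non-aromatic and of carbon only, so a small step is expected, probably none beyond the scatter. The expected step is a 1.3-fold lower number from compound 3 to compound 4 (0.10 log units; within the scatter). Compound 4 is estimated at 12000 nM, with an expected range of 4000 nM to 40000 nM.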

Compound 4, half-maximal inhibitory concentration: > 100000 nM
Compound 4 ended at the assay's limit (the forecaster's own chance of this, stated with the estimate: 8%); middle value at least 8.3-fold (0.92 log units) from the limit.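

Ring size at this nitrogen matters: replacing cyclohexyl with the larger carbon-only cyclooctyl ring gives an at least 6.6-fold higher number from compound 3 to compound 4 (0.82 log units; beyond the scatter) in this assay, so a swap between two non-aromatic rings with no hydrogen-bond donors or acceptors can clearly weaken inhibition. Set against the 2,4-dichlorophenyl group, the cyclooctyl group gives an at least 22-fold higher number from compound 2 to compound 4 (1.34 log units; beyond the scatter). Compound 4 gives > 100000 nM, which is a limit and not a number, so both steps are minimum sizes and the step between compound 1 and compound 4 cannot be read: the limit of > 100000 nM in this assay, at which 2 of the 4 values shown sit.

Where inhibition falls away between the two ring sizes stays open, and a cycloheptyl group on this nitrogen would address that. Also open, as far as these compounds go, is whether a cyclopentyl ring, or a cyclohexyl ring carrying an amine, would give a lower number than compound 3.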